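A Nitro for Trifluoromethyl Swap on a Weak Inhibitor

This account rests on a few compounds, and the source may have more. Where it says the series, first, only, none or still open, it means among the compounds named here.

Going by the values given here, compound 1 `O=C(Nc1cccc(-c2oc3cc(-c4ccc(F)cc4)ccc3c(=O)c2O)c1)c1ccc(C(F)(F)F)cc1` holds the only actual number among the values shown: in a functional assay on HepG2 cells (Homo sapiens) for antiproliferative activity, read by CCK-8 assay, with a stated time of 72 h (a lower number here means a stronger inhibitor, a higher number a weaker inhibitor), compound 1 gives 42700 nM. Compound 2 `O=C(Nc1cccc(-c2oc3cc(-c4ccc(F)cc4)ccc3c(=O)c2O)c1)c1cnc(Cl)nc1Cl` reaches only a limit of the assay, and in this assay compound 2 gives > 100000 nM. Among the compounds with values here, the single measured comparison is an at least 2.3-fold higher number from compound 1 to compound 2 (0.36 log units; beyond the scatter), and it replaces the whole ring on the carbonyl carbon; the value the limit of > 100000 nM in this assay, at which 1 of the 2 values shown sits, marks where one of the two results sits. Compound 3 `O=C(Nc1cccc(-c2oc3cc(-c4ccc(F)cc4)ccc3c(=O)c2O)c1)c1ccc([N+](=O)[O-])cc1` changes compound 1 in a smaller way: nitro in place of trifluoromethyl on an aromatic carbon. Within the data shown here, no measured step alters only this group, so the one known step offers limited guidance beyond showing that, in that one case, altering this ring did not strengthen the compound. Only a small shift is expected, namely a 1.2-fold higher number from compound 1 to compound 3 (0.07 log units; within the scatter). Compound 3 is therefore estimated at 50000 nM, with a range from 15000 nM to 150000 nM.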

Compound 3, half-maximal inhibitory concentration: 1860 nM
Compound 3: the middle estimate sits 27-fold (1.43 log units) above what was measured; measured number outside the range, below it.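

In this assay, nitro in place of trifluoromethyl, para to a large group, gives a 23-fold lower number from compound 1 to compound 3 (1.36 log units; beyond the scatter), so one small group at this position can shift the result strongly towards a stronger inhibitor, which the earlier step between compounds did not show. Exchanging the whole ring on the carbonyl carbon gives an at least 53-fold lower number from compound 2 to compound 3 (1.73 log units; beyond the scatter), a step that rests on a limit of the assay for compound 2 and so marks a gap of unknown full size. The data shown give no measured property that accounts for the gain from this swap.

As far as these compounds go, whether the gain is special to nitro stays open, since an amine, a carboxylic acid or a nitrile at this same position would test that. Also open, from the compounds shown here alone, is how nitro would fare at another position on this ring.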